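Trifluoromethyl for methyl: expectation for compound 3

The compounds below may be only part of what the source reports. "The series", "measured", "known", "first", "only" and "open" are said of these compounds alone.

Measured so far in an assay on CHO cells for displacement of a labelled ligand from prostaglandin E2 receptor EP1 subtype (Homo sapiens); a higher number here means a weaker inhibitor, a lower number a stronger inhibitor:
compound 1, `CCOc1ccc(Cc2nnc(CN(c3cccc(Cl)c3C)S(=O)(=O)c3ccc(C)cc3)o2)cc1`: 3.98 nM
compound 2, `CCOc1ccc(Cc2nnc(CN(c3cccc(Cl)c3Cl)S(=O)(=O)c3ccc(C)cc3)o2)cc1`: 6.31 nM

Within the data shown here, compound 2 sits within the scatter of compound 1; the only measured step, a 1.6-fold higher number from compound 1 to compound 2 (0.20 log units; within the scatter), is the exchange of chloro for methyl on an aromatic carbon of the other aryl group, not the one changed below.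

Compound 3, `CCOc1ccc(Cc2nnc(CN(c3cccc(Cl)c3Cl)S(=O)(=O)c3ccc(C(F)(F)F)cc3)o2)cc1`, differs from compound 2 by trifluoromethyl in place of methyl on an aromatic carbon. Among the measured compounds shown here, no measured step touches this carbon or this ring, so the one step on record gives no guide to direction or size, and nothing in the two numbers at hand argues for a change beyond the scatter.

Compound 3 is therefore expected to give about 8 nM in this assay, with a plausible range of 2.5 nM to 25 nM.

The expected step from compound 2 to compound 3 is a 1.3-fold higher number from compound 2 to compound 3 (0.10 log units; within the scatter), an estimate carrying the wide uncertainty of an untested change.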

Compound 3, half-maximal inhibitory concentration: 2.51 nM
The estimate for compound 3 lay 3.2-fold (0.50 log units) above the measured number; the measured number falls inside the stated range.
By their numbers in this assay, from the lowest: compounds 3, 1 and 2 (each within the scatter of the next, the first and the last beyond it).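

In this assay, the exchange of 4-methylphenyl for 4-(trifluoromethyl)phenyl gives a 2.5-fold lower number from compound 2 to compound 3 (0.40 log units; beyond the scatter). Among these compounds, this is the first sign that the number responds to a change at this ring, and the step is modest but beyond the scatter, unlike the earlier exchange of chloro for methyl on the other aryl group. The larger trifluoromethyl group is accepted at this carbon without any loss in this read-out, but nothing measured here accounts for the step.

From the compounds shown here alone, it remains open whether the same exchange would give a similar step on compound 1, which carries methyl rather than chloro on the other aryl group. Also open, going by these compounds, is how a nitrile, a carboxylic acid or a plain hydrogen on this carbon would read in this assay.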